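The compounds below may be only part of what the source reports. "The series", "measured", "known", "first", "only" and "open" are said of these compounds alone.

Measured compounds:
Compound 1, `Cc1cccnc1NC(=O)NC1=NC(=O)CN1C`, 1900 nM in a functional assay for inhibition of metabotropic glutamate receptor 5 (Homo sapiens), read by FLIPR and calcium flux; on this read-out higher numbers stand for weaker inhibition and lower numbers for stronger inhibition
Compound 2, `CCN1C(NC(=O)Nc2cccc(Cl)c2)=NC(=O)C1C`, 410 nM in this assay
Compound 3, `O=C(NC1=NC(=O)C2CCCN12)Nc1cccc(Cl)c1`, 800 nM in this assay

Among these three, compound 3 stands second highest. Its nearest neighbour is compound 2, whose number lies within the scatter of that of compound 3, so the two cannot be told apart on this read-out. Compound 1 stands furthest off, with a higher number than compound 3 that lies beyond the scatter, so compound 3 is the stronger inhibitor of that pair.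

The next compound, compound 4, `O=C(NC1=NC(=O)C2CCCN12)Nc1ccccc1`, differs from compound 3 in one place: hydrogen in place of chloro on an aromatic carbon. For the measured compounds named here, no step of exactly this kind exists among the measured compounds, so the expectation rests on the whole set. Both compounds carrying the chloro group, compound 2 and compound 3, show the lower numbers of the set, which is taken as a hint that removing it may cost some inhibition. The step from compound 3 to compound 4 is therefore expected to be a 3.1-fold higher number from compound 3 to compound 4 (0.49 log units; beyond the scatter), modestly towards a higher number, perhaps just beyond the scatter. For compound 4 the expected value in this assay is 2500 nM, with a range from 900 nM to 7000 nM.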

Compound 4, half-maximal inhibitory concentration: 4200 nM
The estimate for compound 4 lay 1.7-fold (0.23 log units) below the measured number; the range from low to high includes it.
By their numbers in this assay, from the lowest: compounds 2 and 3 (each within the scatter of the next); then compound 1; then compound 4.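

In this assay, hydrogen in place of chloro on an aromatic carbon gives a 5.3-fold higher number from compound 3 to compound 4 (0.72 log units; beyond the scatter) and lies beyond the scatter. For the compounds shown here, this is the first reading of the chloro group with the rest of the molecule unchanged, since the earlier compounds differed from one another in more than one place. At this place, meta to a large group, on this core, the chloro compound is thus the stronger inhibitor of the pair. Nothing at hand accounts for the size of this step or for what the chloro group contributes.

As far as these compounds go, it remains open whether fluoro, bromo, methyl, methoxy or a nitrile at this place would match chloro or go beyond it. From the compounds shown here alone, it also remains open whether the same step would appear on the core of compound 2.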